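Working notes on solubility across compounds 1 to 4

A few compounds are considered here, and "the series" means these few. Any claim that something is new, unique, unknown or untested is made for them only; others in the source may bear on it.

Measured so far:
Compound 1, `CNC(=O)c1cc(Oc2ccc3nc(Nc4ccc(F)cc4)ncc3c2)ccn1`, gives < 1000 nM in a physicochemical assay for solubility, at pH 7; on this read-out lower numbers stand for lower solubility and higher numbers for higher solubility; this is a limit of the assay, not a number.
Compound 2, `CNC(=O)c1cc(Oc2ccc3nc(Nc4ccc(Br)cc4)ncc3c2)ccn1`, gives < 1000 nM in this assay, again a limit of the assay.
Compound 3, `CNC(=O)c1cc(Oc2ccc3nc(Nc4ccc(C(F)(F)F)cc4)ncc3c2)ccn1`, gives < 1000 nM in this assay, also a limit of the assay.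

Compound 3 therefore stands at the limit of < 1000 nM in this assay, at which 3 of the 3 values shown sit, and nothing separates it from the other two on the numbers shown. The steps leading to it are a step that the two limits leave unreadable from compound 1 to compound 3 and a step that the two limits leave unreadable from compound 2 to compound 3, and the remaining step among the measured compounds, a step that the two limits leave unreadable from compound 1 to compound 2, is of the same kind. None of them carries a readable size.

Compound 4, `CNC(=O)c1cc(Oc2ccc3nc(Nc4ccc(Oc5ccccc5)cc4)ncc3c2)ccn1`, differs from compound 3 by phenoxy in place of trifluoromethyl on an aromatic carbon. The measured steps give no size to carry over, so no step beyond the scatter in this assay is expected, and compound 4 is expected to sit at the same limit as the three measured compounds. For compound 4 the estimate in this assay is 400 nM, within 80 nM to 2000 nM. The estimated step is a step that the limit leaves unreadable from compound 3 to compound 4, expected not to register as a number.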

Compound 4, solubility: < 1000 nM
Compound 4 ended at the assay's limit (the forecaster's own chance of this, stated with the estimate: 80%); the middle value lies beyond the limit too.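

The steps among compound 1, compound 2, compound 3 and compound 4 cannot be read in this assay, and all four compounds share one limit: the limit of < 1000 nM in this assay, at which 4 of the 4 values shown sit. The compounds shown leave open whether fluoro, bromo, trifluoromethyl and phenoxy differ at all in this assay.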